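A few compounds are considered here, and "the series" means these few. Any claim that something is new, unique, unknown or untested is made for them only; others in the source may bear on it.

Going by the values given here, compound 3 `O=C(N[C@H](CO)C(=O)NO)c1ccc(C#Cc2ccccc2)cc1` sits second highest of the three numbers measured so far in a physicochemical assay for solubility (on this read-out lower numbers stand for lower solubility and higher numbers for higher solubility), where compound 3 gives 36000 nM. Its nearest neighbour is compound 1 `O=C(N[C@@H](CO)C(=O)NO)c1ccc(C#Cc2ccccc2)cc1`, which in this assay gives 28000 nM; the two differ only in configuration as drawn (the fact that compounds 1 and 3 differ only in the configuration as drawn), and the step of a 1.3-fold higher number from compound 1 to compound 3 (0.11 log units; within the scatter) stays within the scatter. Compound 2 `NC(=O)C[C@H](NC(=O)c1ccc(C#Cc2ccccc2)cc1)C(=O)NO` gives 61000 nM in this assay, and the step of a 2.2-fold higher number from compound 1 to compound 2 (0.34 log units; beyond the scatter) is the only one so far that goes beyond the scatter.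

Compound 4 `O=C(CNC(=O)c1ccc(C#Cc2ccccc2)cc1)NO` has not yet been measured. It differs from compound 3 by hydrogen in place of hydroxymethyl on a saturated chain carbon bound to an amide-type nitrogen and a carbonyl carbon. Neither measured step matches this change: one swaps configuration, the other swaps carbamoyl for hydroxy, and the one beyond the scatter was modest. The step to compound 4 is therefore expected to be a 1.4-fold lower number from compound 3 to compound 4 (0.16 log units; within the scatter), close to the scatter. Compound 4 is expected to give about 25000 nM in this assay, with a range from 8000 nM to 80000 nM.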

Compound 4, solubility: 21000 nM
For compound 4 the middle estimate is 1.2-fold (0.08 log units) above the measured one; the range from low to high includes it.
By their numbers in this assay, from the lowest: compounds 4, 1, 3 and 2 (each within the scatter of the next, the first and the last beyond it).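

Replacing hydroxymethyl with hydrogen on a saturated chain carbon bound to an amide-type nitrogen and a carbonyl carbon stays within the scatter in this assay from either drawn configuration (a 1.7-fold lower number from compound 3 to compound 4 (0.23 log units; within the scatter); a 1.3-fold lower number from compound 1 to compound 4 (0.12 log units; within the scatter)). These two readings concern one change made from two starting compounds that are otherwise alike: the fact that compounds 1 and 3 differ only in the configuration as drawn. Replacing carbamoylmethyl with hydrogen at the same carbon does go beyond the scatter (a 2.9-fold lower number from compound 2 to compound 4 (0.46 log units; beyond the scatter)), so among these compounds only the carbamoylmethyl and hydrogen pair is clearly separated by a change at this carbon.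

From the compounds shown here alone, whether an amine, a carboxylic acid or a longer chain at this carbon would fall with hydroxymethyl or with carbamoylmethyl remains open. Also open, going by these compounds, is how the two drawn configurations compare when carbamoylmethyl is the group at this carbon.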